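This account rests on a few compounds, and the source may have more. Where it says the series, first, only, none or still open, it means among the compounds named here.

Working notes on the series. The shared core carries two hydroxyphenyl groups and one five-membered heteroaryl group on a six-membered aromatic ring with one nitrogen. Compound 1 `Oc1ccccc1-c1cc(-c2ccsc2)cc(-c2ccccc2O)n1` and compound 2 `Oc1ccc(-c2cc(-c3ccsc3)cc(-c3ccccc3O)n2)cc1` each carry a 2-hydroxyphenyl group and a thiophen-3-yl group; compound 3 `Oc1ccc(-c2cc(-c3ccsc3)cc(-c3ccc(O)cc3)n2)cc1` carries two 4-hydroxyphenyl groups. In an assay on isolated protein for inhibition of DNA topoisomerase 1 (Homo sapiens), with a stated time of 30 min, tested at 20 uM (a higher number here means a stronger effect of the compound at the concentration tested, a lower number a weaker effect), compound 3 gives 7.5%, a weak effect at the tested concentration. In this assay compound 2 gives "not determined" (no result reported) and compound 1 gives "not determined" (no result reported), so compound 2 stands without a measured result and with only compound 3 as a point of reference.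

Compound 4 `Oc1ccc(-c2cc(-c3ccoc3)cc(-c3ccccc3O)n2)cc1` differs from compound 2 in one place: furan-3-yl in place of thiophen-3-yl on an aromatic carbon. Among the measured compounds shown here, no step between measured compounds of this kind is recorded, so the size of the step from compound 2 to compound 4 in this assay cannot be read from a pair of numbers. Given that the only measured value, compound 3 at 7.5%, lies close to the scatter of the read-out, the expectation for compound 4 is a similarly small inhibition, with no change beyond the scatter anticipated. Compound 4 is estimated at 8% in this assay, with a range from 0% to 20%.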

Compound 4, a percentage reported as inhibition, at one concentration (the size of the read-out at that concentration, not a potency): 3.9%
Estimate against measurement, compound 4: 4.1 percentage points above; the range from low to high includes it.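

In this assay, among the compounds shown here, compound 2 gives "not determined" (no result reported) and compound 4 gives 3.9%, so no step between these two compounds can be read. The compounds shown leave open whether furan-3-yl in place of thiophen-3-yl changes the inhibition at all. Nothing at hand bears on a cause for the result of compound 4.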